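This account rests on a few compounds, and the source may have more. Where it says the series, first, only, none or still open, it means among the compounds named here.

Measured in a functional assay on NCI-H1299 cells (Homo sapiens) for inhibition, with a stated time of 48 h, at 37 degrees C; a higher number here means a weaker inhibitor of growth, a lower number a stronger inhibitor of growth:
- compound 1 `FC(F)(F)c1ccc(-c2noc(-c3sccc3Cl)n2)nc1`: > 10000 nM
- compound 2 `Clc1ccc(-c2noc(-c3sccc3Cl)n2)nc1`: > 10000 nM
- compound 3 `FC(F)(F)c1ccc(-c2noc(-c3occc3Br)n2)cc1`: > 10000 nM

Each of these values is a limit of the assay and not a number. Compound 2 therefore has no exact place in the series, and its value of > 10000 nM is only a limit. The same holds for the other two compounds, as the whole record shows: the limit of > 10000 nM in this assay, at which 3 of the 3 values shown sit.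

The step to compound 4 `Clc1ccc(-c2noc(-c3occc3Cl)n2)nc1` exchanges one group on an aromatic carbon, leaving the rest of compound 2 unchanged: 3-chlorofuran-2-yl in place of 3-chlorothiophen-2-yl on an aromatic carbon. Among the compounds with values here, the one measured step is a step that the two limits leave unreadable from compound 1 to compound 2, so it offers no size to carry over to this change. Within the data shown here, no measured step involves this exchange of groups.

Compound 4 is expected to remain inactive in this assay because of the limit of > 10000 nM in this assay, at which 3 of the 3 values shown sit. The expected change is no more than the usual scatter, with no favoured direction: a step that the limit leaves unreadable from compound 2 to compound 4. For compound 4 the estimate is 12000 nM. The estimated range for compound 4 runs from 3000 nM to 30000 nM.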

Compound 4, concentration for 50% growth inhibition: > 10000 nM
Compound 4 gave a limit, no number; the forecaster's own chance of this, stated with the estimate: 80%; the middle value is on the limit's open side.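

Compound 4 gives > 10000 nM, which is a limit and not a number, so the change from compound 2 to compound 4 cannot be read as a step of any size. How strongly any of these compounds inhibits growth stays open, since every result sits at the same limit: the limit of > 10000 nM in this assay, at which 4 of the 4 values shown sit.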